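A few compounds are considered here, and "the series" means these few. Any claim that something is new, unique, unknown or untested is made for them only; others in the source may bear on it.

Measured so far:
Compound 1 `CCN(CC)S(=O)(=O)c1ccc(S(=O)(=O)N2CCC[C@@H](C(=O)NC)C2)cc1`: 8600 nM
Compound 2 `CCN(CC)S(=O)(=O)c1ccc(S(=O)(=O)N2CCC[C@@H](c3nc(C)no3)C2)cc1`: 4100 nM

In a functional assay on MIA PaCa-2 cells (Homo sapiens) for inhibition, read by MTT assay, with a stated time of 7 days (a higher number here means a weaker inhibitor, a lower number a stronger inhibitor), compound 2 gives 4100 nM, the lowest of the two numbers; its nearest neighbour is compound 1 with 8600 nM. Going by the values given here, the single measured step, a 2.1-fold lower number from compound 1 to compound 2 (0.32 log units; beyond the scatter), concerns a different exchange on the same saturated ring carbon. Compound 3 `CCN(CC)S(=O)(=O)c1ccc(S(=O)(=O)N2CCC[C@@H](c3cc(C)no3)C2)cc1` differs from compound 2 by 3-methyl-1,2-oxazol-5-yl in place of 3-methyl-1,2,4-oxadiazol-5-yl on a saturated ring carbon. Among the compounds with values here, no measured step bears directly on this change, so the expected step in this assay is none beyond the scatter; the estimated step is a 1.2-fold higher number from compound 2 to compound 3 (0.09 log units; within the scatter). Compound 3 is therefore estimated at 5000 nM, ranging from 2500 nM to 12000 nM.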

Compound 3, half-maximal inhibitory concentration: 4900 nM
Compound 3: middle estimate off by 1.0-fold (0.01 log units), on the high side, and the stated range covers the measured number.
By their numbers in this assay, from the lowest: compounds 2, 3 and 1 (each within the scatter of the next, the first and the last beyond it).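

In this assay, 3-methyl-1,2-oxazol-5-yl in place of 3-methyl-1,2,4-oxadiazol-5-yl on this saturated ring carbon gives a 1.2-fold higher number from compound 2 to compound 3 (0.08 log units; within the scatter), so the five-membered aromatic ring with 2 hetero atoms and the one with 3 are not told apart here. Measured against methylcarbamoyl, 3-methyl-1,2-oxazol-5-yl gives a 1.8-fold lower number from compound 1 to compound 3 (0.24 log units; within the scatter), a step that also stays within the scatter. Nothing available explains either step. Still open, as far as these compounds go, is how an amine, a carboxylic acid or a longer alkyl chain on this carbon would read in this assay.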